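This account rests on a few compounds, and the source may have more. Where it says the series, first, only, none or still open, it means among the compounds named here.

Measured compounds in a functional assay on the whole organism for inhibition, with Rattus norvegicus as the target; on this read-out lower numbers stand for an effect already at smaller amounts and higher numbers for an effect only at larger amounts of compound:
compound 1 `CN(C)C(=O)n1cc(C(=O)c2ccn3c2CSC3c2cccnc2)c2ccc(Cc3ccccc3)cc21`, compound 1 gives 0.09 mg/kg
compound 2 `CN(C)C(=O)n1cc(C(=O)c2ccn3c2CSC3c2cccnc2)c2ccc(-c3ccccc3)cc21`, compound 2 gives 0.03 mg/kg
compound 3 `NC(=O)n1cc(C(=O)c2ccn3c2CSC3c2cccnc2)c2ccc(-c3ccc(F)cc3)cc21`, compound 3 gives 0.01 mg/kg

Compound 3 stands at the lowest of the three numbers in this assay; compound 2 sits above it and compound 1 above that, both gaps beyond the scatter. Among the measured compounds shown here, the only single-point step measured so far is the exchange of the pendant group on the aromatic carbon, a 3.0-fold lower number from compound 1 to compound 2 (0.48 log units; beyond the scatter).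

Compound 4 `CN(C)C(=O)Cn1cc(C(=O)c2ccn3c2CSC3c2cccnc2)c2ccc(-c3ccc(F)cc3)cc21` differs from compound 3 at the aromatic nitrogen of the shared core: (dimethylcarbamoyl)methyl in place of carbamoyl on an aromatic nitrogen. For the measured compounds named here, no measured pair isolates this change. Compounds 1 and 2 carry a different amide on that nitrogen, but each also differs from compound 3 in the pendant group, so their values show only that amides without a donor on that nitrogen are compatible with low numbers in this assay. The step of compound 1 to compound 2 concerns another position and gives no guidance here.

Going by the values given here, with no direct precedent, the expectation for compound 4 is anchored on compound 3 at 0.01 mg/kg, with a wide range. Compound 4 is estimated at 0.02 mg/kg, range 0.006 mg/kg to 0.07 mg/kg. The expected step is a 2.0-fold higher number from compound 3 to compound 4 (0.30 log units; within the scatter), not resolved beyond the scatter.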

Compound 4, dose for half-maximal effect: 0.009 mg/kg
Compound 4: middle estimate off by 2.2-fold (0.35 log units), on the high side, within the range that was stated.
By their numbers in this assay, from the lowest: compounds 4 and 3 (each within the scatter of the next); then compound 2; then compound 1.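

In this assay, among the compounds shown here, the exchange on the aromatic nitrogen gives a 1.1-fold lower number from compound 3 to compound 4 (0.05 log units; within the scatter), the first step that isolates this position on the shared core. With the pendant group held constant, carbamoyl, with 3 heavy atoms and 1 hydrogen-bond donor, and (dimethylcarbamoyl)methyl, with 6 heavy atoms and 0 hydrogen-bond donors, are not resolved from each other, so in this pair neither the donor nor the shorter group is required for a low number on this read-out. No measurement available here bears on why the two groups read alike.

Going by these compounds, it remains open whether the same latitude holds for a carboxylic acid or a primary amine carried on a longer chain at this nitrogen, since both groups compared here are neutral amides. On these data alone, it is also open whether (dimethylcarbamoyl)methyl and carbamoyl stay unresolved in this assay when the pendant group is the phenyl of compound 2 or the benzyl of compound 1.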